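A few compounds are considered here, and "the series" means these few. Any claim that something is new, unique, unknown or untested is made for them only; others in the source may bear on it.

In an ADME assay on the whole organism (Macaca fascicularis) for pharmacokinetics, read by LC-MS, using cassette dosing, at a dose of 1 mg/kg by the oral route (on this read-out higher numbers stand for higher exposure at the dose given and lower numbers for lower exposure), compound 1 `CCCCN(c1nc2c(NC(C)=O)cccc2o1)[C@H](C)c1ccc(-c2ccccc2-c2nnn[nH]2)cc1` gives 26.6 nM, the lowest of the three numbers recorded so far. Compound 3 `CCCCN(c1nc2c(C(=O)O)cccc2o1)[C@H](C)c1ccc(-c2cc(Cl)ccc2-c2nc(=O)o[nH]2)cc1` gives 677 nM in this assay, and compound 2 `C[C@H](c1ccc(-c2cc(F)ccc2-c2nc(=O)o[nH]2)cc1)N(CC1CC1)c1nc2c(C(=O)O)cccc2o1` gives 2900 nM; both of these gaps from compound 1 lie beyond the usual scatter of the measurement. Compound 4 `CCCCN(c1nc2ccccc2o1)[C@H](C)c1ccc(-c2ccccc2-c2nnn[nH]2)cc1` has not yet been measured. It differs from compound 1 in a single place: hydrogen in place of acetamido on an aromatic carbon. Going by the values given here, no pair of measured compounds shows this change by itself, so there is no precedent for its effect in this set. The step is expected to be small, a 1.9-fold higher number from compound 1 to compound 4 (0.27 log units; within the scatter), possibly within the scatter, with a slight lean upward. Compound 4 is therefore estimated at 50 nM in this assay, within a range from 12 nM to 250 nM.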

Compound 4, maximal plasma concentration: 29.2 nM
Estimate against measurement, compound 4: 1.7-fold (0.23 log units) above; the range from low to high includes it.
By their numbers in this assay, from the lowest: compounds 1 and 4 (each within the scatter of the next); then compound 3; then compound 2.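

Hydrogen in place of acetamido on this aromatic carbon gives, in this assay, a 1.1-fold higher number from compound 1 to compound 4 (0.04 log units; within the scatter), the first reading of this change by itself. With the rest of compound 1 held constant, the acetamido group can therefore be absent from this position without a shift beyond the scatter. Nothing measured here offers a reason for this outcome.

On these data alone, whether an amine or a methoxy group on this carbon would also leave the maximal plasma concentration within the scatter remains open. As far as these compounds go, the separate contribution of the carboxylic acid in compound 2 and compound 3 also remains open, as each differs from compound 1 in more than one place.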